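A few compounds are considered here, and "the series" means these few. Any claim that something is new, unique, unknown or untested is made for them only; others in the source may bear on it.

Measured so far in a functional assay on HT-29 cells (Homo sapiens) for inhibition, read by sulforhodamine B assay, with a stated time of 48 h, tested at 10 uM; on this read-out higher numbers stand for more inhibition at the one concentration tested (going by the name of the read-out) and lower numbers for less inhibition:
Compound 1 `COc1ccc(-c2cn3ccnc3c(-c3ccc4ncn(C5CCCCC5)c4c3)n2)cc1` gives 92.5%
Compound 2 `O=Cc1ccc(-c2cn3ccnc3c(-c3ccc4ncn(C5CCCCC5)c4c3)n2)cc1` gives 17.5%
Compound 3 `CC(=O)c1ccc(-c2cn3ccnc3c(-c3ccc4ncn(C5CCCCC5)c4c3)n2)cc1` gives 9.2%

Compound 3 stands lowest of the three numbers in this assay; compound 2 lies nearest, the two being within the scatter of each other, and compound 1 lies furthest, its number beyond the scatter. Compound 4 `Clc1ccc(-c2cn3ccnc3c(-c3ccc4ncn(C5CCCCC5)c4c3)n2)cc1` has not yet been measured. It differs from compound 3 in one place: chloro in place of acetyl on an aromatic carbon. For the measured compounds named here, no measured step exchanges a chloro group, so none bears on it directly. The steps that touch the same aromatic carbon are a number 75 percentage points lower from compound 1 to compound 2 (beyond the scatter) and a number 83.3 percentage points lower from compound 1 to compound 3 (beyond the scatter), both large drops when a carbonyl-bearing group replaces methoxy, while a number 8.3 percentage points lower from compound 2 to compound 3 (within the scatter) stays within the scatter. Chloro carries no carbonyl and no hydrogen-bond acceptor, which the two low compounds share, so the step of a number 35.8 percentage points higher from compound 3 to compound 4 (beyond the scatter) is expected to run upward, though its size is uncertain. The estimate for compound 4 in this assay is therefore 45%, within a range from 10% to 90%.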

Compound 4, a percentage reported as inhibition, at one concentration (the size of the read-out at that concentration, not a potency): 16.4%
Compound 4: the middle estimate sits 28.6 percentage points above what was measured; the measured number falls inside the stated range.
By their numbers in this assay, from the lowest: compounds 3, 4 and 2 (each within the scatter of the next); then compound 1.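

In this assay the steps of a number 7.2 percentage points higher from compound 3 to compound 4 (within the scatter) and a number 1.1 percentage points lower from compound 2 to compound 4 (within the scatter) show that, at this aromatic carbon, chloro, with no carbonyl and no hydrogen-bond acceptor, does not separate from acetyl or formyl. The step of a number 76.1 percentage points lower from compound 1 to compound 4 (beyond the scatter) places chloro with those two groups, so a carbonyl is not required for a low number here, and among the four groups only methoxy stands apart. Nothing at hand explains what sets methoxy apart.

As far as these compounds go, whether the high number belongs to methoxy alone or extends to ethoxy, hydroxy or a dimethylamino group on this carbon stays open. Also open, from the compounds shown here alone, is whether any of these four compounds would separate differently at concentrations other than the single one tested.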